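Swapping a Methoxyphenyl for a Methylthiophene on Two Cores

The compounds below may be only part of what the source reports. "The series", "measured", "known", "first", "only" and "open" are said of these compounds alone.

Of the compounds shown here, three have so far been measured in an ADME assay on Vero cells (Chlorocebus sabaeus) for cytotoxicity, read by MTT assay, with a stated time of 72 h; on this read-out lower numbers stand for stronger inhibition and higher numbers for weaker inhibition. Compound 1 `COc1ccc(-c2ccnc(Nc3ccc(C(=O)O)cc3)n2)cc1` carries a carboxylic acid and a 4-methoxyphenyl group. In this assay compound 1 reaches only > 100000 nM, which is a limit of the assay and not a number (the limit of > 100000 nM in this assay, at which 1 of the 3 values shown sits). Compound 3 `Cc1csc(-c2ccnc(Nc3ccc(C(=O)O)cc3)n2)c1` keeps the carboxylic acid but carries 4-methylthiophen-2-yl instead (4-methylthiophen-2-yl in place of 4-methoxyphenyl on an aromatic carbon). In this assay compound 3 gives 80800 nM. The step is an at least 1.2-fold lower number from compound 1 to compound 3 (0.09 log units; that floor lies within the scatter), so the exchange left the read-out essentially where it was.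

Compound 2 `COc1ccc(-c2ccnc(Nc3cccc(C(N)=O)c3)n2)cc1` belongs to a second core; how it differs from the core of compound 1 is not broken down here. In this assay compound 2 gives 2700 nM, the lowest of the numbers measured.

Compound 4 `Cc1csc(-c2ccnc(Nc3cccc(C(N)=O)c3)n2)c1` has not yet been measured. It stands to compound 2 as compound 3 stands to compound 1: 4-methylthiophen-2-yl in place of 4-methoxyphenyl on an aromatic carbon. Since the place is described in the same words both times, this is the same change as before. Compound 4 is expected to show a step of a 1.2-fold lower number from compound 2 to compound 4 (0.09 log units; within the scatter). That expectation rests on compound 1 and compound 3, whose step of an at least 1.2-fold lower number from compound 1 to compound 3 (0.09 log units; that floor lies within the scatter) stayed within the scatter, and on compound 2 with its 2700 nM as the starting point. Compound 4 is therefore estimated at 2200 nM, with a likely span from 1000 nM to 5000 nM.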

Compound 4, half-maximal inhibitory concentration: > 100000 nM
Compound 4 was reported as a limit; the forecaster's own chance of this, stated with the estimate: 5%; middle value at least 45-fold (1.65 log units) from the limit.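

In this assay compound 4 gives > 100000 nM, which is a limit of the assay and not a number. On the core of compound 2, placing 4-methylthiophen-2-yl where 4-methoxyphenyl stood gave an at least 37-fold higher number from compound 2 to compound 4 (1.56 log units; beyond the scatter), so the near absence of any effect on the core of compound 1 did not carry over, and the outcome of this exchange depended on the core: the same change on two cores in this assay, an at least 1.2-fold lower number (0.09 log units; that floor lies within the scatter) from compound 1 to compound 3 and an at least 37-fold higher number (1.56 log units; beyond the scatter) from compound 2 to compound 4, at least 45-fold (1.66 log units) apart, beyond the scatter of two such steps Two pairs give no rule for any other core and no reason for the difference, and the full size of each step remains unknown, since each rests on a limit: the limit of > 100000 nM in this assay, at which 2 of the 4 values shown sit.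

The two cores differ by more than a single feature, so the compounds shown do not reveal which part of the core of compound 2 goes with the large step. From the compounds shown here alone, it also remains open whether a plain phenyl, or a thiophene without its methyl, would behave on that core like 4-methoxyphenyl or like 4-methylthiophen-2-yl, and whether a nitrile in place of the amide would give the same contrast.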